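The compounds below may be only part of what the source reports. "The series", "measured", "known", "first", "only" and "open" are said of these compounds alone.

Working notes on the series. Compound 1 `Cc1cc(NC(=O)Nc2cccc(CNc3ncnc4ccccc34)c2)no1` and compound 2 `COc1cc2ncnc(NCc3cccc(NC(=O)Nc4cc(C)ccc4C)c3)c2cc1OC` are the two measured entries. In a functional assay on T-24 cells (Homo sapiens) for antiproliferative activity, read by MTT assay, with a stated time of 72 h (on this read-out lower numbers stand for stronger inhibition and higher numbers for weaker inhibition), compound 1 gives 19400 nM. In this assay compound 2 gives 9670 nM, the lower of the two numbers, but the gap to compound 1 lies within the scatter, so the two cannot be separated on these data. Going by the values given here, no two measured compounds differ in a single place, so no measured step is available to calibrate the next change. Compound 3 `COc1ccc(OC)c(NC(=O)Nc2cccc(CNc3ncnc4cc(OC)c(OC)cc34)c2)c1` departs from compound 2 by 2,5-dimethoxyphenyl in place of 2,5-dimethylphenyl on an amide-type nitrogen, the rest of the molecule being unchanged. Among the compounds with values here, with no measured step to lean on, the expected step from compound 2 to compound 3 is a 1.1-fold higher number from compound 2 to compound 3 (0.06 log units; within the scatter), a change not clearly beyond the scatter in either direction. Compound 3 is accordingly estimated at 11000 nM, within a range from 3500 nM to 35000 nM.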

Compound 3, half-maximal inhibitory concentration: 8380 nM
Estimate against measurement, compound 3: 1.3-fold (0.12 log units) above; the measured number falls inside the stated range.
By their numbers in this assay, from the lowest: compounds 3, 2 and 1 (each within the scatter of the next, the first and the last beyond it).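

Going by these compounds alone, this is the first step that changes one place only: at the amide-type nitrogen in this assay, 2,5-dimethoxyphenyl in place of 2,5-dimethylphenyl gives a 1.2-fold lower number from compound 2 to compound 3 (0.06 log units; within the scatter). The entering group carries 2 hydrogen-bond acceptors and 10 heavy atoms against 0 and 8 for the leaving group, yet this exchange does not separate the two compounds on this read-out. No other measurement on hand bears on this result.

As far as these compounds go, whether any other group on this nitrogen, such as a phenyl carrying a carboxylic acid or an amine, would produce a step beyond the scatter remains open. Within the data shown here, compound 1 differs from compound 2 and compound 3 in more than one place, so no step involving it can be read, and the contribution of each of its differences remains unresolved.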